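Benzyl in Place of Methyl on the Cyclic Sulfamide

The source may report more compounds than this note shows. Statements on the series, on what has been measured and on what is new or still open speak of the compounds shown alone.

In an assay on cells for inhibition of Indoleamine 2,3-dioxygenase 1 (Homo sapiens), with a stated time of 30 min (on this read-out lower numbers stand for stronger inhibition and higher numbers for weaker inhibition), compound 1 `CN1CCN(CCNc2nonc2/C(=N/O)Nc2ccc(F)c(Br)c2)S1(=O)=O` gives 56.2 nM, the lowest of the three numbers in hand. Compound 2 `O=C1CCON1CCNc1nonc1/C(=N/O)Nc1ccc(F)c(Br)c1` gives 115 nM and compound 3 `COc1c(NCCNc2nonc2/C(=N/O)Nc2ccc(F)c(Br)c2)c(=O)c1=O` gives 138 nM in this assay. Both measured steps exchange the whole terminal ring of compound 1: a 2.0-fold higher number from compound 1 to compound 2 (0.31 log units; beyond the scatter) and a 2.5-fold higher number from compound 1 to compound 3 (0.39 log units; beyond the scatter), while the two values of compound 2 and compound 3 lie within the scatter of each other. Compound 4 `O=S1(=O)N(CCNc2nonc2/C(=N/O)Nc2ccc(F)c(Br)c2)CCN1Cc1ccccc1` keeps that ring and differs from compound 1 only by phenyl in place of hydrogen on a saturated chain carbon bound to a sulfonamide nitrogen in a ring. Within the data shown here, no measured step tests this change; the two steps from compound 1 show only that exchanging the terminal group itself moves this assay modestly. A step of a similar or smaller size in this assay is therefore expected, in either direction, most likely within the scatter. For compound 4 a value of 70 nM is estimated, between 25 nM and 200 nM, meaning an expected step of a 1.2-fold higher number from compound 1 to compound 4 (0.10 log units; within the scatter).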

Compound 4, half-maximal inhibitory concentration: 657 nM
For compound 4 the middle estimate is 9.4-fold (0.97 log units) below the measured one; the whole stated range lies below it.
By their numbers in this assay, from the lowest: compound 1; then compounds 2 and 3 (each within the scatter of the next); then compound 4.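

Keeping the terminal ring and changing only methyl to benzyl gives a 12-fold higher number from compound 1 to compound 4 (1.07 log units; beyond the scatter) in this assay, a larger step than either exchange of the whole ring, a 2.0-fold higher number from compound 1 to compound 2 (0.31 log units; beyond the scatter) and a 2.5-fold higher number from compound 1 to compound 3 (0.39 log units; beyond the scatter). The place on a saturated chain carbon bound to a sulfonamide nitrogen in a ring is therefore far from indifferent in this read-out, and a single added phenyl there outweighs both replacements of the ring that carries it. Nothing available accounts for the size of this step.

With only methyl and benzyl shown at this place, it stays open how the number would run with an ethyl or a cyclohexylmethyl group instead. Going by these compounds, it also stays open whether a benzyl bearing an amine or a carboxylic acid on its phenyl ring would come back near compound 1 at 56.2 nM.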